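Ester variation in an adenine hydroxypropanoate series: cytotoxicity notes

The source may report more compounds than this note shows. Statements on the series, on what has been measured and on what is new or still open speak of the compounds shown alone.

Measured so far:
Compound 1, `CCCCCCCCOC(=O)C(O)Cn1cnc2c(N)ncnc21`: 200 ug/mL
Compound 2, `CCCCCOC(=O)C(O)Cn1cnc2c(N)ncnc21`: 200 ug/mL

In a functional assay on Vero cells (Chlorocebus sabaeus) for cytotoxicity (on this read-out lower numbers stand for higher toxicity in this test and higher numbers for lower toxicity in this test), compound 1 gives 200 ug/mL and compound 2 gives 200 ug/mL; the step of no change at the digits printed from compound 1 to compound 2 (within the scatter) leaves compound 2 level with compound 1 within the scatter.

Compound 3, `CC(C)(C)OC(=O)C(O)Cn1cnc2c(N)ncnc21`, is not yet measured. It differs from compound 2 by tert-butyl in place of pentyl on an oxygen next to a carbonyl group. Among the compounds with values here, the only step that bears on this change is no change at the digits printed from compound 1 to compound 2 (within the scatter), which was flat. In this assay a step of no change at the digits printed from compound 2 to compound 3 (within the scatter) is therefore expected, nothing beyond the scatter. Compound 3 is estimated at 200 ug/mL, with a range from 100 ug/mL to 400 ug/mL.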

Compound 3, minimum cytotoxic concentration: > 400 ug/mL
Compound 3: only a limit was reported (the forecaster's own chance of this, stated with the estimate: 30%); at least 2.0-fold (0.30 log units) between middle value and limit.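

In this assay compound 3 stands only as a limit, not a number: > 400 ug/mL. Tert-butyl on an oxygen next to a carbonyl group gives an at least 2.0-fold higher number from compound 2 to compound 3 (0.30 log units; that floor lies within the scatter), and against octyl it gives an at least 2.0-fold higher number from compound 1 to compound 3 (0.30 log units; that floor lies within the scatter). So this position now has a change that does not end level with the earlier esters at a shared number, though the true size of the step stays unfixed: the limit of > 400 ug/mL in this assay, at which 1 of the 3 values shown sits.

As far as these compounds go, how far compound 3 lies past that limit remains open. So does whether a carboxylic acid, an amide or an isopropyl ester at this place would read as a number.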